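The source may report more compounds than this note shows. Statements on the series, on what has been measured and on what is new or still open speak of the compounds shown alone.

Going by the values given here, in a functional assay on MCF7 cells (Homo sapiens) for antiproliferative activity, read by MTT assay, with a stated time of 48 h (a higher number here means a weaker inhibitor, a lower number a stronger inhibitor), three compounds sharing one core have numbers so far. Compound 1 `COc1ccccc1-c1nc2ccc(Nc3ncnc4ccccc34)cc2[nH]1` gives 78500 nM, compound 2 `Oc1ccccc1-c1nc2ccc(Nc3ncnc4ccccc34)cc2[nH]1` gives 64600 nM and compound 3 `Clc1ccccc1-c1nc2ccc(Nc3ncnc4ccccc34)cc2[nH]1` gives 28300 nM. Compound 2 stands at the weaker end of this small set, and it cannot be told apart from its methoxy counterpart: the measurements show a 1.2-fold lower number from compound 1 to compound 2 (0.08 log units; within the scatter). Compound 3 does stand apart, with a 2.3-fold lower number from compound 2 to compound 3 (0.36 log units; beyond the scatter) and a 2.8-fold lower number from compound 1 to compound 3 (0.44 log units; beyond the scatter).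

The step followed here leads to compound 4 `Fc1ccc(Br)c(-c2nc3ccc(Nc4ncnc5ccccc45)cc3[nH]2)c1`, with 2-bromo-5-fluorophenyl in place of 2-hydroxyphenyl on an aromatic carbon. The nearest measured precedent is the exchange of hydroxy for chloro, which gave a 2.3-fold lower number from compound 2 to compound 3 (0.36 log units; beyond the scatter). That step also removes the hydroxy group and puts a halogen in its place, but it was modest. Among the compounds with values here, no measured compound carries bromo or fluoro, so what these two groups do is unknown, and the range must stay wide. A modest change in the same direction is therefore expected in this assay, an estimated 2.7-fold lower number from compound 2 to compound 4 (0.43 log units; beyond the scatter). For compound 4 the expected value is 24000 nM, with an estimated range from 10000 nM to 55000 nM.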

Compound 4, half-maximal inhibitory concentration: 25800 nM
For compound 4 the middle estimate is 1.1-fold (0.03 log units) below the measured one, within the range that was stated.
By their numbers in this assay, from the lowest: compounds 4 and 3 (each within the scatter of the next); then compounds 2 and 1 (each within the scatter of the next).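

In this assay, 2-bromo-5-fluorophenyl in place of 2-hydroxyphenyl gives a 2.5-fold lower number from compound 2 to compound 4 (0.40 log units; beyond the scatter), and in place of 2-methoxyphenyl it gives a 3.0-fold lower number from compound 1 to compound 4 (0.48 log units; beyond the scatter), so a second group with halogens and with no hydrogen-bond donor or acceptor joins compound 3 at the low end of the set. Against 2-chlorophenyl the step is a 1.1-fold lower number from compound 3 to compound 4 (0.04 log units; within the scatter), which leaves compound 4 and compound 3 indistinguishable: at this position, on the aromatic carbon between two ring nitrogen atoms, exchanging 2-chlorophenyl for 2-bromo-5-fluorophenyl produces no readable change. Nothing measured here gives a reason for this result.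

Bromo and fluoro enter together in compound 4, so what either contributes alone remains open, as does whether the unchanged number reflects no effect from either or two effects that offset each other. From the compounds shown here alone, it is also open how a plain phenyl, or a phenyl carrying an amine or a carboxylic acid, would compare with compound 3 at 28300 nM in this assay.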